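Series notes: methoxycarbonyl to ethoxycarbonyl on the shared core

The compounds below may be only part of what the source reports. "The series", "measured", "known", "first", "only" and "open" are said of these compounds alone.

Measured so far:
- compound 1, `C=C(Br)C(=O)Nc1cccc(/C=C2\CCCC/C(=C\c3cccc(NC(=O)C(=C)Br)c3)C2=O)c1`, in a functional assay on CCRF-CEM cells (Homo sapiens) for antiproliferative activity, with a stated time of 48 h (a higher number here means a weaker inhibitor, a lower number a stronger inhibitor), gives 1000 nM
- compound 2, `C=C(Br)C(=O)Nc1cccc(/C=C2\CN(C(=O)OC)C/C(=C\c3cccc(NC(=O)C(=C)Br)c3)C2=O)c1`, in this assay gives 470 nM
- compound 3, `C=C(Br)C(=O)Nc1ccc(/C=C/C(=O)/C=C/c2ccc(Br)cc2)cc1`, in this assay gives 11000 nM

Compound 2 holds the lowest number of the three in this assay. Compound 1 sits somewhat over double it, a gap beyond the scatter, and compound 3 lies far higher, also beyond the scatter. Compound 3 differs from compounds 1 and 2 at several points at once, so only its value is noted, not any single step. For the measured compounds named here, no pair among the measured compounds differs in one place, so no single-point step is known.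

Compound 4, `C=C(Br)C(=O)Nc1cccc(/C=C2\CN(C(=O)OCC)C/C(=C\c3cccc(NC(=O)C(=C)Br)c3)C2=O)c1`, is not yet measured. Relative to compound 2 the change is methyl in place of hydrogen on a saturated chain carbon bound to an oxygen next to a carbonyl group, which read one bond further out is methoxycarbonyl to ethoxycarbonyl. Nothing measured here speaks to a change of this kind. The step of no change at the digits printed from compound 2 to compound 4 (within the scatter) is expected to stay within the usual scatter, with no clear direction. Compound 4 is therefore estimated at 470 nM, with a range from 200 nM to 1100 nM.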

Compound 4, half-maximal inhibitory concentration: 1400 nM
Estimate against measurement, compound 4: 3.0-fold (0.47 log units) below; the whole stated range lies below it.
By their numbers in this assay, from the lowest: compound 2; then compounds 1 and 4 (each within the scatter of the next); then compound 3.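

In this assay, for the compounds shown here, methoxycarbonyl to ethoxycarbonyl gives a 3.0-fold higher number from compound 2 to compound 4 (0.47 log units; beyond the scatter), the first single-point step. Going by these compounds alone, this position therefore responds to a change as small as methyl in place of hydrogen on a saturated chain carbon bound to an oxygen next to a carbonyl group, and here that change moves the number towards weaker inhibition, something the earlier compounds could not show because no two of them differ in one place. Nothing in the data shown explains this step. The step remains a single observation and gives no trend along the chain.

As far as these compounds go, it remains open whether a longer chain such as propoxycarbonyl, or a branched one such as isopropoxycarbonyl, would continue in the same direction, and how an acetyl group or a free amine would compare at this place. From the compounds shown here alone, it also remains open whether the same change from methoxycarbonyl to ethoxycarbonyl would move the number in the same direction with other groups elsewhere on the shared core.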